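The compounds below may be only part of what the source reports. "The series", "measured", "known", "first", "only" and "open" are said of these compounds alone.

Values in an ADME assay on HepG2 cells (Homo sapiens) for cytotoxicity, with a stated time of 72 h; a lower number here means that less compound is needed, a higher number that more compound is needed for the effect:
Compound 1 `Cc1cc(NC(=O)Nc2cccc(C(N)=O)c2)c2ccccc2n1`: > 25000 nM (a limit)
Compound 2 `Cc1cc(NC(=O)Nc2cccc(F)c2)c2ccccc2n1`: > 25000 nM (a limit)
Compound 3 `Cc1cc(NC(=O)Nc2cccc(N(C)C)c2)c2ccccc2n1`: > 25000 nM (a limit)

These three compounds share one core and differ only in a single group on an aromatic carbon. Compound 3 has no exact number, because its > 25000 nM is a limit and not a measured value. Compound 1 and compound 2 are no different, and all three sit at the limit of > 25000 nM in this assay, at which 3 of the 3 values shown sit.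

The next compound to be tested is compound 4 `Cc1cc(NC(=O)Nc2cccc(OC(F)(F)F)c2)c2ccccc2n1`. It carries trifluoromethoxy in place of dimethylamino on an aromatic carbon, meta to a large group: trifluoromethoxy in place of dimethylamino on an aromatic carbon.

For the measured compounds named here, three measured steps bear on this change, since each swaps one group on an aromatic carbon. They are a step that the two limits leave unreadable from compound 1 to compound 2, a step that the two limits leave unreadable from compound 1 to compound 3 and a step that the two limits leave unreadable from compound 2 to compound 3. None of them has a readable size, so there is no measured size to carry over to the new step. All that can be taken from them is that carbamoyl, fluoro and dimethylamino all end at the same limit. A further limit is therefore the likeliest result, although trifluoromethoxy is new among these compounds and a true number could still appear.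

The expected step, a number no higher from compound 3 to compound 4 (the limit leaves the size open), is none beyond the scatter in either direction. Compound 4 is estimated at 25000 nM, with an expected range from 12000 nM to 50000 nM.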

Compound 4, half-maximal effective concentration: 13000 nM
Compound 4: middle estimate off by 1.9-fold (0.28 log units), on the high side; the range from low to high includes it.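

Among the four groups at this position on the shared core, trifluoromethoxy alone gives a measured number in this assay, while the other three compounds each end at the same limit: the limit of > 25000 nM in this assay, at which 3 of the 4 values shown sit.

Set against those limits, the result reads as an at least 1.9-fold lower number from compound 3 to compound 4 (0.28 log units; that floor lies within the scatter), as an at least 1.9-fold lower number from compound 2 to compound 4 (0.28 log units; that floor lies within the scatter) and as an at least 1.9-fold lower number from compound 1 to compound 4 (0.28 log units; that floor lies within the scatter); each of these is only a floor, and the true size of each step stays unknown while the compound it starts from has no exact number. The steps among compound 1, compound 2 and compound 3 cannot be read, so the change to trifluoromethoxy is the only one here that gives this position a number at all, though that floor does not by itself set compound 4 apart from the others.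

As far as these compounds go, what remains open is whether a measured number is particular to trifluoromethoxy or would also appear with a close relative such as trifluoromethyl or methoxy at the same place. From the compounds shown here alone, it is equally open how a carboxylic acid or a longer chain there would read in this assay.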